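The compounds below may be only part of what the source reports. "The series", "measured", "known", "first", "only" and "open" are said of these compounds alone.

Three compounds share one core and differ in a single group on an aromatic carbon: compound 1 `CC1=C(C)C(=O)C(C(CCCCCC(=O)O)c2ccc(Cl)cc2)=C(C)C1=O`, compound 2 `CC1=C(C)C(=O)C(C(CCCCCC(=O)O)c2ccc(Br)cc2)=C(C)C1=O` and compound 3 `COc1ccc(C(CCCCCC(=O)O)C2=C(C)C(=O)C(C)=C(C)C2=O)cc1`. In a functional assay (aorta) with Oryctolagus cuniculus as the target (a higher number here means a weaker inhibitor, a lower number a stronger inhibitor), compound 1 gives 280 nM and compound 2 gives 1700 nM. Compound 2 therefore has the higher of the two numbers and is the weaker inhibitor of the pair.

The change from compound 2 to compound 3 is methoxy in place of bromo on an aromatic carbon, para to a large group: methoxy in place of bromo on an aromatic carbon. Among the compounds with values here, only one measured step bears on this change, bromo in place of chloro on an aromatic carbon. That step is modest but beyond the scatter: a 6.1-fold higher number from compound 1 to compound 2 (0.78 log units; beyond the scatter). Within the data shown here, it shows that this assay responds to a swap at this kind of carbon, but no methoxy compound has been measured, so the direction remains uncertain.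

Among the measured compounds shown here, compound 2 at 1700 nM holds the higher of only two numbers, so a modest move towards a lower number is expected in this assay, smaller than the measured step. The estimated change is a 2.4-fold lower number from compound 2 to compound 3 (0.39 log units; beyond the scatter). Compound 3 is expected at 700 nM, with an estimated range of 150 nM to 3000 nM.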

Compound 3, half-maximal inhibitory concentration: 3000 nM
For compound 3 the middle estimate is 4.3-fold (0.63 log units) below the measured one; low and high end bracket the measured number.
By their numbers in this assay, from the lowest: compound 1; then compounds 2 and 3 (each within the scatter of the next).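

In this assay the swap of 4-bromophenyl to 4-methoxyphenyl gives a 1.8-fold higher number from compound 2 to compound 3 (0.25 log units; within the scatter) and so leaves compounds 2 and 3 indistinguishable here, even though one bromine atom has been replaced by a group of carbon and oxygen that adds a hydrogen-bond acceptor. Against chloro the same methoxy group gives an 11-fold higher number from compound 1 to compound 3 (1.03 log units; beyond the scatter) as a large step, which, together with the earlier bromo step, makes compound 1 the strongest inhibitor of the three and shows that at this carbon the chloro group alone stands apart, while bromo and methoxy cannot be separated. Nothing available explains why this one group differs from the other two.

Within the data shown here, with only three groups in hand, it remains open whether chloro is a special case or whether other groups at this carbon, such as fluoro, an amine or a carboxylic acid, would match or pass it. Among these compounds, it is also unknown whether the same ranking would hold with a longer chain in place of the one shared by these compounds.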